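The compounds below may be only part of what the source reports. "The series", "measured", "known", "first", "only" and "open" are said of these compounds alone.

For the measured compounds named here, in an ADME assay on HeLa cells (Homo sapiens) for cytotoxicity, read by MTT assay, with a stated time of 2 days (on this read-out higher numbers stand for lower toxicity in this test and lower numbers for higher toxicity in this test), compound 3 `CNC(=O)c1cc(Oc2ccc3cc(C(=O)OC(C)C)n(C)c3c2)ccn1` gives 46100 nM, the higher of the two actual numbers measured so far. The nearest value belongs to compound 1 `CNC(=O)c1ccc(Oc2ccc3c(C)c(C(=O)OC(C)C)sc3c2)cn1`, which gives 12900 nM, and this gap lies beyond the scatter. Compound 2 `CCOC(=O)c1cc2ccc(Oc3ccnc(C(=O)NC)c3)cc2o1` is reported only as a limit, > 100000 nM.

Compound 4 `CNC(=O)c1cc(Oc2ccc3c(C)c(C(=O)OC(C)C)n(C)c3c2)ccn1` is compound 3 with methyl in place of hydrogen on an aromatic carbon, next to the ring atom that bears an isopropoxycarbonyl group: methyl in place of hydrogen on an aromatic carbon. Going by the values given here, no measured pair shows this change on its own, so the expectation is loose. Compound 1 also carries a methyl group on its core, though it differs in other ways, and its 12900 nM is the only hint, pointing towards a lower number in this assay. The estimated step of a 1.5-fold lower number from compound 3 to compound 4 (0.19 log units; within the scatter) is therefore small, in that direction, and is expected to stay within the scatter. For compound 4 the estimated value is 30000 nM, with an expected range of 11000 nM to 75000 nM.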

Compound 4, half-maximal cytotoxic concentration: 8500 nM
Beside the measured number, compound 4's estimate is 3.5-fold (0.55 log units) above it; the whole stated range lies above it.
By their numbers in this assay, from the lowest: compounds 4 and 1 (each within the scatter of the next); then compound 3. At a limit, above all of these: compound 2.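

In this assay methyl in place of hydrogen on this aromatic carbon gives a 5.4-fold lower number from compound 3 to compound 4 (0.73 log units; beyond the scatter) and this is the only pair shown that differs in one place. Before it, the only hint was the methyl group on the core of compound 1, a compound that differs in other ways as well, whereas here the change stands alone and a single added carbon on this position of the shared core moves the number beyond the scatter. The data shown give no measured property that would account for this step.

On these data alone, it remains open whether an ethyl group, a chlorine atom or a hydroxymethyl group on the same aromatic carbon would move the number as methyl does. As far as these compounds go, it also remains open whether methyl has the same effect here with a group other than isopropoxycarbonyl on the neighbouring ring atom, such as an ethyl ester or a carboxylic acid.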